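Swapping a benzyl group for an anilinomethyl group

This account rests on a few compounds, and the source may have more. Where it says the series, first, only, none or still open, it means among the compounds named here.

Measured compounds and their numbers:
compound 1, `CCc1ccccc1N(Cc1nnc(Cc2ccccc2)o1)S(=O)(=O)c1ccc(C)cc1`, gives 1000 nM in an assay on CHO cells for displacement of a labelled ligand from prostaglandin E2 receptor EP1 subtype (Homo sapiens); on this read-out lower numbers stand for stronger inhibition and higher numbers for weaker inhibition.
compound 2, `Cc1ccc(S(=O)(=O)N(Cc2nnc(Cc3ccc(C(F)(F)F)cc3)o2)c2cccc(Cl)c2C)cc1`, gives 50.1 nM in this assay.
compound 3, `Cc1ccc(S(=O)(=O)N(Cc2nnc(Cc3ccccc3F)o2)c2cccc(Cl)c2C)cc1`, gives 501 nM in this assay.

Compound 1 has the highest of the three numbers. Compound 3 sits closest to it, and the gap between them lies within the scatter of the measurement. Compound 2 stands furthest away, with a number well beyond the scatter below compound 1.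

Compound 4, `CCc1ccccc1N(Cc1nnc(CNc2ccc(OC)cc2)o1)S(=O)(=O)c1ccc(C)cc1`, differs from compound 1 in one place: (4-methoxyphenyl)amino in place of phenyl on a saturated chain carbon bound to an aromatic carbon. Within the data shown here, no measured step covers this exchange. Among the measured compounds shown here, the only step available, a 10-fold higher number from compound 2 to compound 3 (1.00 log units; beyond the scatter), shows that changing the group on the saturated chain carbon bound to an aromatic carbon can shift the number by a modest but real amount. That step involves a different pair of groups and a different core, so it gives only a rough sense of scale, not a direction. The expected step from compound 1 to compound 4 in this assay is therefore a 1.4-fold lower number from compound 1 to compound 4 (0.15 log units; within the scatter), with wide uncertainty. Compound 4 is estimated at 700 nM, within a range from 150 nM to 3000 nM.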

Compound 4, half-maximal inhibitory concentration: 501 nM
Compound 4: the middle estimate sits 1.4-fold (0.15 log units) above what was measured, within the range that was stated.
By their numbers in this assay, from the lowest: compound 2; then compounds 3, 4 and 1 (each within the scatter of the next).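

In this assay, replacing phenyl with (4-methoxyphenyl)amino on a saturated chain carbon bound to an aromatic carbon gives a 2.0-fold lower number from compound 1 to compound 4 (0.30 log units; within the scatter). So this place accepts a larger group that brings a nitrogen link, a hydrogen-bond donor and hydrogen-bond acceptors without a change that can be told from the scatter, although the earlier step on another core, a 10-fold higher number from compound 2 to compound 3 (1.00 log units; beyond the scatter), showed that an exchange at this place can move the number by a real amount. No measurement shown here explains why this exchange leaves the number within the scatter.

The exchange brings in the nitrogen link and the methoxy group together, so the compounds shown cannot separate what each contributes, and a plain phenylamino group or a small methylamino group at this place would help to tell them apart. Going by these compounds, compound 1 and compound 2 differ in more than one place, so it also remains open whether a 4-(trifluoromethyl)phenyl group would lower the number on the core of compound 1.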